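Shifting One Methoxy Group and Watching Cytotoxicity Change

This account rests on a few compounds, and the source may have more. Where it says the series, first, only, none or still open, it means among the compounds named here.

Of the compounds shown here, three built on one shared core have been tested in a functional assay on MCF7 cells (Homo sapiens) for cytotoxicity, read by MTT assay, with a stated time of 72 h; a lower number here means a stronger inhibitor, a higher number a weaker inhibitor. Compound 1 `COc1cccc(/C=C2\CCC/C(=C\c3cccc(OC)c3OC)C2=O)c1` gives 5900 nM in this assay. Compound 2 `COc1ccc(/C=C2\CCC/C(=C\c3cccc(OC)c3OC)C2=O)cc1` differs from compound 1 in a single place, (4-methoxyphenyl in place of 3-methoxyphenyl on a double-bonded chain carbon bound to a double-bonded ring carbon), and in this assay compound 2 gives 18600 nM. That one change produced a 3.2-fold higher number from compound 1 to compound 2 (0.50 log units; beyond the scatter).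

Compound 3 `COc1cccc(/C=C2\CCC/C(=C\c3ccc(OC)c(OC)c3)C2=O)c1` gives 4600 nM in this assay. How the core of compound 3 differs from the core of compound 1 is not broken down here. Its number is the lowest of the three, yet compound 1 sits within the usual scatter of it, so no order between those two can be claimed. Compound 2, with 18600 nM, lies beyond the scatter from compound 3.

Compound 4 `COc1ccc(/C=C2\CCC/C(=C\c3ccc(OC)c(OC)c3)C2=O)cc1` has not yet been measured in this assay. It stands to compound 3 exactly as compound 2 stands to compound 1: 4-methoxyphenyl in place of 3-methoxyphenyl on a double-bonded chain carbon bound to a double-bonded ring carbon. The place is the same in both pairs, so this is the same change, occurring twice among these four compounds. The step of a 3.0-fold higher number from compound 3 to compound 4 (0.48 log units; beyond the scatter) is therefore expected in this assay, because the same change gave a 3.2-fold higher number from compound 1 to compound 2 (0.50 log units; beyond the scatter) and nothing else in the data argues against a repeat. On that basis compound 4 is estimated at 14000 nM in this assay, with a likely range from 6000 nM to 35000 nM.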

Compound 4, half-maximal inhibitory concentration: 7800 nM
Estimate against measurement, compound 4: 1.8-fold (0.25 log units) above, and the stated range covers the measured number.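

On the second core, the change from 3-methoxyphenyl to 4-methoxyphenyl gives, in this assay, a 1.7-fold higher number from compound 3 to compound 4 (0.23 log units; within the scatter), so this step taken alone cannot be told apart from repeat measurement. Set beside the earlier step, it is not separated from it by more than the scatter, and both pairs print a higher number for the 4-methoxyphenyl compound, so nothing here indicates that the change behaves differently on the two cores: the same change on two cores in this assay, a 3.2-fold higher number (0.50 log units; beyond the scatter) from compound 1 to compound 2 and a 1.7-fold higher number (0.23 log units; within the scatter) from compound 3 to compound 4, 1.9-fold (0.27 log units) apart, within the scatter of two such steps. This does not show that the step has one fixed size or that it would carry to a further core, for only two pairs are shown, just one of them lies beyond the scatter, and the numbers do not say what sets the size of either step.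

What the compounds shown leave open is how the same change would behave with something other than methoxy groups on the aromatic rings, such as a hydroxyl group, a fluorine atom or an amine. Also open, as far as these compounds go, is whether the two steps would keep their size and direction in any assay other than this one.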